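Adding one oxygen to the sulfur ring of compound 3

This account rests on a few compounds, and the source may have more. Where it says the series, first, only, none or still open, it means among the compounds named here.

Compound 1 `O=C1CC(CCc2ccccc2)SS1`: 258000 nM
Compound 2 `O=C1CC(CCc2ccccc2)[S+]([O-])S1`: 68400 nM
Compound 3 `CC1(C)O[C@H]([C@H]2COC(C)(C)O2)[C@@H](C2CC(=O)SS2)O1`: 35900 nM

All three compounds were tested in a functional assay on HeLa cells (Homo sapiens) for cytotoxicity, read by MTT assay; on this read-out lower numbers stand for stronger inhibition and higher numbers for weaker inhibition. There, compound 3 gives 35900 nM, the lowest number of the set, although it lies within the scatter of compound 2 at 68400 nM. The distance from compound 3 to compound 1 at 258000 nM is beyond the scatter, so only compound 1 stands clearly apart.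

Compound 4 `CC1(C)O[C@H]([C@H]2COC(C)(C)O2)[C@@H](C2CC(=O)S[S+]2[O-])O1` has not yet been measured in this assay. It keeps the shared core of compound 3, and the change sits on a saturated ring carbon: a group of 7 heavy atoms (3 carbon, 2 oxygen, 2 sulfur; one five-membered non-aromatic ring with 2 hetero atoms) in place of a group of 6 heavy atoms (3 carbon, 1 oxygen, 2 sulfur; one five-membered non-aromatic ring with 2 hetero atoms), on a saturated ring carbon. The group that enters adds one oxygen to the count of the group that leaves.

Among the measured compounds shown here, no direct step between measured compounds speaks to this change. The nearest guide is the pair of values from the two smaller compounds, where the lower number belongs to compound 2 at 68400 nM and the higher number to compound 1 at 258000 nM. On that basis, a moderate move toward a lower number is expected, and the expected step is a 2.8-fold lower number from compound 3 to compound 4 (0.44 log units; beyond the scatter). This remains uncertain, and a result within the scatter of compound 3 would not be surprising. For compound 4 the estimated value is 13000 nM, with an expected range from 4500 nM to 38000 nM.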

Compound 4, half-maximal inhibitory concentration: 18200 nM
Compound 4: the middle estimate sits 1.4-fold (0.15 log units) below what was measured; the measured number falls inside the stated range.
By their numbers in this assay, from the lowest: compounds 4, 3 and 2 (each within the scatter of the next, the first and the last beyond it); then compound 1.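

Among the compounds shown here, on the shared core of compound 3, this is the first direct measure of adding an oxygen to the sulfur ring: in this assay, the group of 7 heavy atoms in place of the group of 6 heavy atoms, on a saturated ring carbon, gives a 2.0-fold lower number from compound 3 to compound 4 (0.30 log units; within the scatter). Before this, the only view of that added oxygen came from the two smaller compounds, with compound 1 at 258000 nM and compound 2 at 68400 nM, and this step now shows that on the larger core the change cannot be told apart from the scatter of repeated measurements. Nothing in the available data accounts for this outcome, and no measurement on the compounds themselves bears on it.

The compounds shown leave open how a sulfone, with two oxygens on the ring sulfur, would read in this assay, and how an amine or a carboxylic acid would read in place of the sulfur ring at this position. Also open, from the compounds shown here alone, is how an ethyl group would read in place of the two methyl groups on the ring atom that bears them.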